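The source may report more compounds than this note shows. Statements on the series, on what has been measured and on what is new or still open speak of the compounds shown alone.

Compound 2 `CCCc1nc(C)c2cnn(C)c(=O)n12` is the only one of the two measured compounds with a definite number: in a functional assay for inhibition, with Homo sapiens as the target (on this read-out lower numbers stand for stronger inhibition and higher numbers for weaker inhibition), compound 2 gives 20000 nM. Compound 1 `CCCc1nc(C)c2cnn(CC3CC3)c(=O)n12` is known only as a limit, > 48000 nM, in this assay. Across that pair the read-out fell an at least 2.4-fold lower number from compound 1 to compound 2 (0.38 log units; beyond the scatter), so replacing a larger group on that chain carbon by hydrogen gave a lower number. Compound 3 `CCCc1nc(C)c2cnn(C/C=C/C(=O)OCC)c(=O)n12` goes the other way: 2-(ethoxycarbonyl)ethenyl in place of hydrogen on a saturated chain carbon bound to an aromatic nitrogen. Among the measured compounds shown here, since the single comparable step punished a bulkier group there, compound 3 is expected to give a somewhat higher number, a 1.8-fold higher number from compound 2 to compound 3 (0.24 log units; within the scatter), estimated at 35000 nM within 12000 nM to 100000 nM.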

Compound 3, half-maximal inhibitory concentration: > 48000 nM
Compound 3 gave a limit, no number; the forecaster's own chance of this, stated with the estimate: 35%; middle value at least 1.3-fold (0.13 log units) from the limit.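

With the 2-(ethoxycarbonyl)ethenyl group, this assay shows an at least 2.4-fold higher number from compound 2 to compound 3 (0.38 log units; beyond the scatter). Cyclopropyl is therefore no lone case: two different groups, one with a ring and one without, both give a higher number than hydrogen on this saturated chain carbon bound to an aromatic nitrogen. The step between those two groups cannot be read, since both compounds stop at a limit: the limit of > 48000 nM in this assay, at which 2 of the 3 values shown sit.

As far as these compounds go, how far either group lies past that limit stays open. So does whether ethyl, an amine or a carboxylic acid at this place would match compound 2 or give a lower number.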